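The compounds below may be only part of what the source reports. "The series", "measured", "known", "first", "only" and "open" are said of these compounds alone.

Measured in an ADME assay on HEK293 cells (Homo sapiens) for cytotoxicity, read by MTT assay, with a stated time of 48 h; a higher number here means a weaker inhibitor, a lower number a stronger inhibitor:
compound 1 `Cc1ccc(S(=O)(=O)/N=C(/CCNC2=CC(=O)c3ccccc3C2=O)Nc2ccc(F)cc2)cc1`: 55100 nM
compound 2 `Cc1ccc(S(=O)(=O)/N=C(/CCNC2=CC(=O)c3ccccc3C2=O)NCc2ccccc2)cc1`: 80200 nM

Compound 1 and compound 2 lie within the scatter of each other, as the step of a 1.5-fold higher number from compound 1 to compound 2 (0.16 log units; within the scatter) shows, so neither stands apart. Compound 3 `Cc1ccc(S(=O)(=O)/N=C(/CCNC2=CC(=O)c3ccccc3C2=O)NC2CCCCC2)cc1` differs from compound 1 by cyclohexyl in place of 4-fluorophenyl on an amine nitrogen. Among the compounds with values here, the only step that bears on this position is the one from compound 1 to compound 2, and it stayed within the scatter; no step with cyclohexyl exists here. Compound 3 is therefore expected to change little, with the step of a 1.1-fold higher number from compound 1 to compound 3 (0.04 log units; within the scatter). The estimate for compound 3 is 60000 nM, between 25000 nM and 140000 nM.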

Compound 3, half-maximal inhibitory concentration: 50100 nM
Estimate against measurement, compound 3: 1.2-fold (0.08 log units) above, and the stated range covers the measured number.
By their numbers in this assay, from the lowest: compounds 3, 1 and 2 (each within the scatter of the next).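

In this assay, the step of a 1.1-fold lower number from compound 1 to compound 3 (0.04 log units; within the scatter) and the step of a 1.6-fold lower number from compound 2 to compound 3 (0.20 log units; within the scatter) both lie within the scatter. The amine nitrogen therefore now carries a non-aromatic ring, an aromatic ring and a benzyl group, and these three compounds cannot be told apart in this assay. Nothing available explains this. The compounds shown leave open whether a group of another kind on this nitrogen, such as a carboxylic acid or an amine at the end of a longer chain, would give a number beyond the scatter.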